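Biaryl tropane series: thiophene in place of methylphenyl

The source may hold more compounds than are shown below. What is called first, only, known or untested is meant among the compounds shown, and "the series" means these compounds.

Measured so far:
compound 1 `COC(=O)C1C2CCC3CCC1N(C/C2=C\c1ccc(-c2ccc(C)cc2)cc1)C3` — 214 nM
compound 2 `COC(=O)C1C2CCC3CCC1N(C/C2=C\c1ccc(-c2cccc(Cl)c2)cc1)C3` — 89 nM

Within the data shown here, in an assay with sodium-dependent dopamine transporter (Rattus norvegicus) as the target (on this read-out higher numbers stand for weaker inhibition and lower numbers for stronger inhibition), compound 1 gives 214 nM, the higher of the two numbers; the only step is a 2.4-fold lower number from compound 1 to compound 2 (0.38 log units; beyond the scatter). Compound 3 `COC(=O)C1C2CCC3CCC1N(C/C2=C\c1ccc(-c2ccc(C)s2)cc1)C3` differs from compound 1 by 5-methylthiophen-2-yl in place of 4-methylphenyl on an aromatic carbon. Among the measured compounds shown here, no measured step exchanges the six-membered ring for a five-membered one, so the step to compound 2 bears on it only as a sign that this position tolerates change. For compound 3 the expected step is a 1.3-fold lower number from compound 1 to compound 3 (0.10 log units; within the scatter), a small shift that may well fall within the scatter. Compound 3 is estimated at 170 nM, with a range from 70 nM to 420 nM.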

Compound 3, inhibition constant: 674 nM
Compound 3: middle estimate off by 4.0-fold (0.60 log units), on the low side; measured number above the stated range.
By their numbers in this assay, from the lowest: compound 2; then compound 1; then compound 3.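

In this assay the position para to a large group proves sensitive to ring type: 5-methylthiophen-2-yl in place of 4-methylphenyl gives a 3.1-fold higher number from compound 1 to compound 3 (0.50 log units; beyond the scatter) and so moves opposite to the earlier 3-chlorophenyl change. Against 3-chlorophenyl the same group gives a 7.6-fold higher number from compound 2 to compound 3 (0.88 log units; beyond the scatter) and compound 3 has the highest number of the three. The tolerance suggested by the first two compounds therefore does not extend to this five-membered ring. No evidence at hand bears on this result.

As far as these compounds go, whether the higher number follows the ring size or the sulfur stays open. A furan-2-yl group or a 5-chlorothiophen-2-yl group at this position would bear on that question.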